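The source may hold more compounds than are shown below. What is called first, only, known or untested is meant among the compounds shown, and "the series" means these compounds.

Three compounds have been measured in an assay on isolated protein for inhibition of DNA topoisomerase 1 (Homo sapiens), with a stated time of 30 min, tested at 100 uM; a lower number here means less inhibition, a higher number more inhibition at the concentration tested (going by the name of the read-out):
Compound 1 `Oc1ccc(-c2cc(-c3ccccc3O)nc(-c3ccccc3O)c2)cc1` gives 3.7%.
Compound 2 `Oc1cccc(-c2cc(-c3ccccc3O)cc(-c3ccccc3O)n2)c1` gives 0%.
Compound 3 `Oc1cccc(-c2cc(-c3ccccc3O)cc(-c3cccc(O)c3)n2)c1` gives 0%.

Compound 3 stands level with compound 2, and the number for compound 1 lies within the usual scatter of both, so none of the three shows inhibition that can be told apart from zero. Compound 4 `Oc1cccc(-c2cc(-c3cccc(O)c3)nc(-c3cccc(O)c3)c2)c1` differs from compound 3 in one place: 3-hydroxyphenyl in place of 2-hydroxyphenyl on an aromatic carbon. Going by the values given here, the only measured step that bears on this is the same kind of swap, no change at the digits printed from compound 2 to compound 3 (within the scatter), which came with no change beyond the scatter. A step of the same kind, none beyond the scatter, is therefore expected here, no change at the digits printed from compound 3 to compound 4 (within the scatter). Compound 4 is accordingly estimated at 0%, with a range from 0% to 8%.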

Compound 4, a percentage reported as inhibition, at one concentration (the size of the read-out at that concentration, not a potency): 0%
Estimate against measurement, compound 4: no gap at the digits printed; measured number inside the range.
By their numbers in this assay, from the lowest: compounds 2, 3, 4 and 1 (each within the scatter of the next).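

In this assay, putting 3-hydroxyphenyl in place of 2-hydroxyphenyl on the carbon opposite the ring nitrogen leaves the number where it was (no change at the digits printed from compound 3 to compound 4 (within the scatter)). This position, meta to two 3-hydroxyphenyl groups, therefore shows no inhibition that can be told apart from zero with either group, and the swap now gives the same outcome at a second place on the shared core. No measurement here offers a reason for this. Still open, on these data alone, is whether an amine or a carboxylic acid on this carbon, in place of the hydroxyphenyl group, would give inhibition clear of zero.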